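The source may report more compounds than this note shows. Statements on the series, on what has been measured and on what is new or still open speak of the compounds shown alone.

Measured so far:
compound 1, `Cc1nc(N)sc1CCCN/C(N)=N/C(=O)NC(C)c1ccc(Cl)cc1`: 24.6 nM
compound 2, `CCCCCCNC(=O)/N=C(\N)NCCCc1sc(N)nc1C`: 15.9 nM

In a functional assay on Right cardiac atrium for agonist activity at histamine H2 receptor (Cavia porcellus), with a stated time of 30 min, in the presence of a further agent that is not named here (a lower number here means that less compound is needed, a higher number that more compound is needed for the effect), compound 2 gives 15.9 nM, and compound 1 gives 24.6 nM; these two values lie within the usual scatter of one another, so neither stands apart. Compound 3, `Cc1nc(N)sc1CCCN/C(N)=N/C(=O)NC(C)c1cccs1`, has not yet been measured. It differs from compound 2 in one place: 1-(thiophen-2-yl)ethyl in place of hexyl on an amide-type nitrogen. Compound 1 also differs from compound 2 at the amide-type nitrogen, and the value of compound 1, 24.6 nM, sits within the scatter of that of compound 2, so no step beyond the scatter is expected here. For compound 3 the expected value is 20 nM, with a range of 8 nM to 50 nM, which would mean an expected step of a 1.3-fold higher number from compound 2 to compound 3 (0.10 log units; within the scatter).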

Compound 3, half-maximal effective concentration: 10 nM
The estimate for compound 3 lay 2.0-fold (0.30 log units) above the measured number; low and high end bracket the measured number.
By their numbers in this assay, from the lowest: compounds 3, 2 and 1 (each within the scatter of the next, the first and the last beyond it).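

In this assay, 1-(thiophen-2-yl)ethyl in place of hexyl on the amide-type nitrogen gives a 1.6-fold lower number from compound 2 to compound 3 (0.20 log units; within the scatter) and so shows that a group with a five-membered aromatic ring serves here as well as an open chain. Thiophen-2-yl in place of 4-chlorophenyl gives a 2.5-fold lower number from compound 1 to compound 3 (0.39 log units; beyond the scatter) and shows a modest effect of which ring is carried. No measurement shown explains either step. As far as these compounds go, whether an amine, a carboxylic acid or a longer chain at this position would give similar numbers stays open.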